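The compounds below may be only part of what the source reports. "The series", "measured", "known", "first", "only" and "open" are said of these compounds alone.

Working notes on the series.

Of the compounds shown here, two of the shared core carry numbers so far. Compound 1 `O=C1C=C(Nc2ccc(F)c(F)c2)C(=O)c2cnccc21` bears a fluoro pair on the aromatic ring; in a functional assay on the whole organism (aorta) with Rattus norvegicus as the target (a higher number here means a larger maximal response, a lower number a smaller maximal response), compound 1 gives 81%. Compound 2 `O=C1C=C(Nc2ccc(F)cc2F)C(=O)c2cnccc21` carries its two fluoro groups in another arrangement, and in this assay compound 2 gives 96%. Of the two numbers, compound 2 holds the higher one, and its nearest neighbour, compound 1, sits lower by a gap beyond the usual scatter. For the measured compounds named here, no step between measured compounds that differ in one place has been worked out.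

Compound 3 `O=C1C=C(Nc2ccc(F)c(F)c2F)C(=O)c2cnccc21` is the next entry and is not yet measured in this assay. It differs from compound 2 in one place: fluoro in place of hydrogen on an aromatic carbon. The new fluoro sits ortho to two fluoro groups and meta to a large group.

Going by the values given here, there is no measured pair to calibrate this change. The expectation for compound 3 is a response near that of compound 2, with the step from compound 2 to compound 3 expected at a number 6 percentage points lower from compound 2 to compound 3 (within the scatter), which lies within the scatter; for compound 3 the estimate is 90%, between 74% and 104%.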

Compound 3, largest response reached (Emax), in percent of the reference or control that the assay uses: 87%
Compound 3: middle estimate off by 3 percentage points, on the high side, within the range that was stated.
By their numbers in this assay, from the lowest: compounds 1, 3 and 2 (each within the scatter of the next, the first and the last beyond it).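

In this assay, fluoro in place of hydrogen on an aromatic carbon now has two readings, a number 9 percentage points lower from compound 2 to compound 3 (within the scatter) and a number 6 percentage points higher from compound 1 to compound 3 (within the scatter), and neither step separates the two compounds it joins. Where the new fluoro sits ortho to two fluoro groups and meta to a large group, the maximal response of compound 3 cannot be told apart from that of compound 2, so this position accepts the added fluoro without a change that can be read in this assay; the earlier compounds offered no step of this kind. Nothing available bears on why the response stays within the scatter across this change.

The compounds shown leave open whether a group other than fluoro on this aromatic carbon, such as chloro, methoxy, a nitrile or an amine, would move the response beyond the scatter. They also leave open whether the same change gives a readable step on a ring carrying fewer fluoro groups, since both steps here start from a ring that already bears a fluoro pair.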